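The source may hold more compounds than are shown below. What is called first, only, known or untested is meant among the compounds shown, and "the series" means these compounds.

Measured so far:
compound 1 `OC[C@H]1O[C@@H](n2cnc3c(NCc4ccc(Cl)cc4)ncnc32)[C@H](O)[C@@H]1O` — 218000 nM
compound 2 `COc1ccccc1CNc1ncnc2c1ncn2[C@@H]1O[C@H](CO)[C@@H](O)[C@H]1O` — 89000 nM
compound 3 `COc1cccc(CNc2ncnc3c2ncn3[C@@H]2O[C@H](CO)[C@@H](O)[C@H]2O)c1OC` — > 166000 nM (a limit, not a number)

In a functional assay on K562 cells (Homo sapiens) for antiproliferative activity, with a stated time of 72 h (on this read-out higher numbers stand for weaker inhibition and lower numbers for stronger inhibition), compound 1 gives 218000 nM, the highest of the two numbers shown. Compound 2 gives 89000 nM. For compound 3 the assay reports only a limit, > 166000 nM; one of the three results sits there (the limit of > 166000 nM in this assay, at which 1 of the 3 values shown sits).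

Compound 4 `COc1ccc(CNc2ncnc3c2ncn3[C@@H]2O[C@H](CO)[C@@H](O)[C@H]2O)c(OC)c1` differs from compound 1 by 2,4-dimethoxyphenyl in place of 4-chlorophenyl on a saturated chain carbon bound to a nitrogen on an aromatic ring. Among the measured compounds shown here, two measured steps bear on this. The first, a 2.4-fold lower number from compound 1 to compound 2 (0.39 log units; beyond the scatter), is modest but beyond the scatter and shares the methoxy on the ring carbon next to the chain attachment. The second, a step that the limit leaves unreadable from compound 1 to compound 3, cannot be read because of the limit, and an at least 1.8-fold higher number from compound 2 to compound 3 (0.27 log units; that floor lies within the scatter) shows that a second methoxy did not add to the gain of compound 2. The change to compound 4 is therefore expected to give a step of the size seen for compound 2 at most, likely a 1.8-fold lower number from compound 1 to compound 4 (0.26 log units; within the scatter), a lower number. Compound 4 is estimated at 120000 nM, with a range from 50000 nM to 300000 nM.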

Compound 4, half-maximal inhibitory concentration: > 166000 nM
Compound 4 was reported as a limit (the forecaster's own chance of this, stated with the estimate: 30%); at least 1.3-fold (0.14 log units) between middle value and limit.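

In this assay compound 4 is reported only as a limit, > 166000 nM, and compound 3 sits at the same limit: the limit of > 166000 nM in this assay, at which 2 of the 4 values shown sit.

Methoxy in place of hydrogen on an aromatic carbon gives an at least 1.8-fold higher number from compound 2 to compound 4 (0.27 log units; that floor lies within the scatter), so neither dimethoxyphenyl compound shows a gain over compound 2, whichever of the two dimethoxyphenyl groups is carried. The steps from compound 1 to compound 4 and from compound 3 to compound 4 cannot be read, so no order among these three compounds can be stated.

The compounds shown leave open how far compound 3 and compound 4 lie beyond their shared limit. Also open, from the compounds shown here alone, is whether an amine or a carboxylic acid on the phenyl ring, or a longer chain in place of the saturated chain carbon, would give a lower number than compound 2 at 89000 nM.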